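The compounds below may be only part of what the source reports. "The series", "measured", "known", "first", "only" and "open" are said of these compounds alone.

Measured compounds:
- compound 1, `COc1ccc2[nH]cc(C(=O)/C(C#N)=C/C=C(\Cl)c3ccc(OC)c(OC)c3)c2c1`: 74.2%
- compound 2, `COc1ccc(/C(Cl)=C/C=C(\C#N)C(=O)c2c[nH]c3ccc(Br)cc23)cc1`: 56.2%
- compound 3, `COc1ccc(/C(Cl)=C/C=C(\C#N)C(=O)c2c[nH]c3ccccc23)cc1`: 76.9%

In a functional assay for inhibition, read by Griess assay, with a stated time of 150 min, tested at 1 mM (a lower number here means less inhibition, a higher number more inhibition at the concentration tested (going by the name of the read-out)), compound 3 gives the highest of the three numbers, though compound 1 lies within the scatter of it and only compound 2 falls clearly lower. Compound 4, `COc1ccc(/C(Cl)=C/C=C(\C#N)C(=O)c2c[nH]c3ccc(OC)cc23)cc1`, differs from compound 3 by methoxy in place of hydrogen on an aromatic carbon. Among the compounds with values here, the one measured step at that kind of position is a number 20.7 percentage points higher from compound 2 to compound 3 (beyond the scatter), a modest change, but it concerns bromo, not methoxy. Compound 1 also carries a methoxy and its value sits close to that of compound 3, so no step beyond the scatter is expected: a number 2.9 percentage points lower from compound 3 to compound 4 (within the scatter). Compound 4 is estimated at 74%, with a range from 60% to 86%.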

Compound 4, a percentage reported as inhibition, at one concentration (the size of the read-out at that concentration, not a potency): 41.6%
Beside the measured number, compound 4's estimate is 32.4 percentage points above it; measured number outside the range, below it.
By their numbers in this assay, from the lowest: compound 4; then compound 2; then compounds 1 and 3 (each within the scatter of the next).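

Within the data shown here, at this position on the shared core, bromo is not the only group that lowers the number in this assay: methoxy in place of hydrogen gives a number 35.3 percentage points lower from compound 3 to compound 4 (beyond the scatter), and methoxy in place of bromo gives a number 14.6 percentage points lower from compound 2 to compound 4 (beyond the scatter). Methoxy here is also not enough on its own to set the result, since hydrogen in place of a methoxy elsewhere gives a number 32.6 percentage points lower from compound 1 to compound 4 (beyond the scatter). Nothing available explains these steps.

From the compounds shown here alone, whether an amine or a hydroxy group at this position would keep the number near that of compound 3 stays open. So does whether fluoro would.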